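Acyl variation on the shared core: expectation for compound 4

This account rests on a few compounds, and the source may have more. Where it says the series, first, only, none or still open, it means among the compounds named here.

Measured so far in an assay on SH-EP1 cells for agonist activity at Neuronal acetylcholine receptor; alpha4/beta2 (Homo sapiens), read by FLIPR and calcium flux; a lower number here means that less compound is needed, a higher number that more compound is needed for the effect:
compound 1 `CC(=O)N1CC2CC(C1)N2` gives 5100 nM
compound 2 `CCC(=O)N1CC2CC(C1)N2` gives 490 nM
compound 3 `O=C(C1CCC1)N1CC2CC(C1)N2` gives 2900 nM

Compound 1 holds the highest of the three numbers in this assay. Its nearest neighbour is compound 3, reached by a 1.8-fold lower number from compound 1 to compound 3 (0.25 log units; within the scatter), a gap that stays within the scatter. Its furthest is compound 2, reached by a 10-fold lower number from compound 1 to compound 2 (1.02 log units; beyond the scatter), a large drop. Between the two larger acyl groups, a 5.9-fold higher number from compound 2 to compound 3 (0.77 log units; beyond the scatter) separates compound 2 from compound 3.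

Compound 4 `O=C([C@H]1C[C@@H]1F)N1CC2CC(C1)N2` differs from compound 1 in one place: 2-fluorocyclopropyl in place of methyl on a carbonyl carbon.

Among the compounds with values here, the steps that bear on this change are those leaving the methyl of compound 1. Going to ethyl gave a 10-fold lower number from compound 1 to compound 2 (1.02 log units; beyond the scatter); going to cyclobutyl gave only a 1.8-fold lower number from compound 1 to compound 3 (0.25 log units; within the scatter). A 2-fluorocyclopropyl group is counted at four heavy atoms, more than ethyl but fewer than cyclobutyl, so a lowering is expected for compound 4, beyond the scatter but short of the step to compound 2, because a 5.9-fold higher number from compound 2 to compound 3 (0.77 log units; beyond the scatter) shows the gain fading as the group grows. The step is estimated as a 3.4-fold lower number from compound 1 to compound 4 (0.53 log units; beyond the scatter).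

For compound 4 in this assay the estimate is 1500 nM, in the range 500 nM to 4500 nM.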

Compound 4, half-maximal effective concentration: 850 nM
Compound 4: the middle estimate sits 1.8-fold (0.25 log units) above what was measured; the measured number falls inside the stated range.
By their numbers in this assay, from the lowest: compounds 2 and 4 (each within the scatter of the next); then compounds 3 and 1 (each within the scatter of the next).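

In this assay, the 2-fluorocyclopropyl group shows that a ring on the carbonyl carbon can keep the lowering seen with ethyl, a point compound 3 alone did not suggest: the change from methyl gives a clear drop (a 6.0-fold lower number from compound 1 to compound 4 (0.78 log units; beyond the scatter)), and the change from cyclobutyl gives a further one (a 3.4-fold lower number from compound 3 to compound 4 (0.53 log units; beyond the scatter)). Compound 4 and compound 2 cannot be told apart (a 1.7-fold higher number from compound 2 to compound 4 (0.24 log units; within the scatter)), so this position now has two different groups that give a similar number, and ring-bearing groups no longer behave as one class here, with compound 3 standing against any rule that a ring gives a lower number than methyl. No measurement at hand accounts for these differences.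

The compounds shown do not separate the contribution of the fluorine from that of the three-membered ring, and a plain cyclopropyl group on the same carbonyl carbon would address that directly. Also open, from the compounds shown here alone, are the role of the two defined stereocentres, which only a different stereoisomer of the 2-fluorocyclopropyl group could test, and how a longer chain such as propyl would compare with ethyl.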